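The compounds below may be only part of what the source reports. "The series", "measured", "known", "first", "only" and "open" are said of these compounds alone.

Of the compounds shown here, three with a shared core have been measured in an assay on cells (strain Sprague-Dawley) for inhibition of Polyunsaturated fatty acid 5-lipoxygenase (Rattus norvegicus), with a stated time of 30 min; a lower number here means a stronger inhibitor, a higher number a weaker inhibitor. Compound 1 `CS(=O)(=O)c1ccc(-c2nc(SCCCOC(=O)/C=C/c3ccc(O)c(O)c3)nn2-c2ccc(Br)cc2)cc1` gives 790 nM. Compound 2 `CS(=O)(=O)c1ccc(-c2nc(SCCCOC(=O)/C=C/c3ccc(O)c(O)c3)nn2-c2ccc(F)cc2)cc1` carries a fluoro where compound 1 carries a bromo. In this assay compound 2 gives 710 nM, and compound 3 `CS(=O)(=O)c1ccc(-c2nc(SCCCNC(=O)/C=C/c3ccc(O)c(O)c3)nn2-c2ccc(F)cc2)cc1`, which links the same side chain through an amide rather than an ester, gives 710 nM. Going by the values given here, the single measured step, a 1.1-fold lower number from compound 1 to compound 2 (0.05 log units; within the scatter), shows that swapping the halogen changes nothing that the assay can resolve, and the numbers of compound 2 and compound 3 are identical, so all three values sit together within the scatter.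

Compound 4 `CS(=O)(=O)c1ccc(-c2nc(SCCCOC(=O)/C=C/c3ccccc3)nn2-c2ccc(Br)cc2)cc1` differs from compound 1 at the far end of the side chain: phenyl in place of 3,4-dihydroxyphenyl on a double-bonded chain carbon bound to a double-bonded chain carbon. Among the compounds with values here, no measured step touches this part of the molecule; the halogen swap and the ester-to-amide pair both leave the dihydroxyphenyl group untouched, so they offer no guide to its removal. Without a precedent, the loss of both hydroxyls is treated as a change that may well matter, and compound 4 is expected to give a higher number, by roughly a 3.8-fold higher number from compound 1 to compound 4 (0.58 log units; beyond the scatter). The estimate for compound 4 in this assay is therefore 3000 nM, with a plausible range from 900 nM to 12000 nM.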

Compound 4, half-maximal inhibitory concentration: 1300 nM
Estimate against measurement, compound 4: 2.3-fold (0.36 log units) above, and the stated range covers the measured number.
By their numbers in this assay, from the lowest: compounds 2, 3, 1 and 4 (each within the scatter of the next).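

In this assay, the 3,4-dihydroxyphenyl group at the far end of the side chain can be replaced by plain phenyl and the result stays within the usual scatter: a 1.6-fold higher number from compound 1 to compound 4 (0.22 log units; within the scatter). Going by these compounds alone, the earlier compounds varied only the halogen and the link in the side chain, so this pair is the first to test this end of the molecule, and it shows that, at least alongside the bromo and the ester of compound 1, the two hydroxyl groups can be absent without a change this assay can resolve. The data at hand offer no explanation for why the two compounds read alike.

As far as these compounds go, this conclusion rests on a single pair, so it remains open whether the same replacement would also leave the number unchanged in the fluoro ester compound 2 or the fluoro amide compound 3. Also open, from the compounds shown here alone, is how this assay would respond to other changes on the same side chain, such as a methoxy group or an amine on the phenyl ring, a carboxylic acid at that end, or a longer chain linking that end to the core.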